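Swapping 2-methoxyphenyl for 4-methoxyphenyl on the shared core

This account rests on a few compounds, and the source may have more. Where it says the series, first, only, none or still open, it means among the compounds named here.

Measured so far in a functional assay on A549 cells (Homo sapiens) for cytotoxicity, read by MTT assay, with a stated time of 72 h; on this read-out higher numbers stand for weaker inhibition and lower numbers for stronger inhibition:
- Compound 1 `COc1ccc(/C=C2\CCC/C(=C\c3ccc(Cl)cc3)C2=O)cc1OC`: 10100 nM
- Compound 2 `COc1ccccc1/C=C1\CCC/C(=C\c2ccc(OC)c(OC)c2)C1=O`: > 20000 nM

Compound 2 has no exact number, only a limit: the limit of > 20000 nM in this assay, at which 1 of the 2 values shown sits. The next compound, compound 3 `COc1ccc(/C=C2\CCC/C(=C\c3ccc(OC)c(OC)c3)C2=O)cc1`, has 4-methoxyphenyl in place of 2-methoxyphenyl on a double-bonded chain carbon bound to a double-bonded ring carbon. For the measured compounds named here, the one measured step at this place is an at least 1.9-fold higher number from compound 1 to compound 2 (0.29 log units; that floor lies within the scatter), where 2-methoxyphenyl replaced 4-chlorophenyl. That step gives only a floor, so it sets no firm size for the new change. Compound 1, with 4-chlorophenyl at that place, gives 10100 nM, so a number in that region is expected for compound 3. Compound 3 may still give only a limit. The expected change in this assay is a modest one toward a lower number, an at least 1.6-fold lower number from compound 2 to compound 3 (0.22 log units; that floor lies within the scatter). For compound 3 the estimate is 12000 nM, with an expected range of 5000 nM to 28000 nM.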

Compound 3, half-maximal inhibitory concentration: > 20000 nM
Compound 3: a limit, no number (the forecaster's own chance of this, stated with the estimate: 30%); middle value at least 1.6-fold (0.22 log units) away from the limit.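

In this assay, moving the methoxy from 2-methoxyphenyl to 4-methoxyphenyl on a double-bonded chain carbon leaves compound 3 with a limit rather than a number, so the step from compound 2 cannot be read. Methoxy in place of chloro on an aromatic carbon gives an at least 1.9-fold higher number from compound 1 to compound 3 (0.29 log units; that floor lies within the scatter), so only a floor is known for this change, not its true size. Of the three compounds, only compound 1 has an exact number, which makes 4-chlorophenyl the only group at this place with a readable value: the limit of > 20000 nM in this assay, at which 2 of the 3 values shown sit.

As far as these compounds go, what exact numbers compound 2 and compound 3 would have stays open. Also open, from the compounds shown here alone, is whether a group carrying an amine or a carboxylic acid on the aromatic ring at this place would give an exact number in this assay.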